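The source may report more compounds than this note shows. Statements on the series, on what has been measured and on what is new or still open speak of the compounds shown alone.

Compound 1 `COc1cc(N2CCNCC2)cnc1Br` and compound 2 `C/C=C\Oc1cncc(N2CCCNCC2)c1` were both tested in an assay (strain Wistar) for binding affinity to Neuronal acetylcholine receptor; alpha4/beta2 (Rattus norvegicus); a lower number here means a stronger inhibitor, a higher number a weaker inhibitor. Compound 1 gives 180 nM, the highest of the two numbers, while compound 2 gives 1.3 nM, a far lower number and a gap beyond the scatter. Compound 3 `Brc1ccc(N2CCNCC2)cn1` differs from compound 1 in one place: hydrogen in place of methoxy on an aromatic carbon. Going by the values given here, no measured pair shows this change, so for the step from compound 1 to compound 3 only a small shift is expected, a 1.7-fold higher number from compound 1 to compound 3 (0.22 log units; within the scatter), not clearly beyond the scatter. Compound 3 is therefore estimated at 300 nM, in a range of 60 nM to 1500 nM.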

Compound 3, half-maximal inhibitory concentration: 180 nM
Estimate against measurement, compound 3: 1.7-fold (0.22 log units) above; low and high end bracket the measured number.
By their numbers in this assay, from the lowest: compound 2; then compounds 1 and 3 (each within the scatter of the next).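

In this assay, hydrogen in place of methoxy on an aromatic carbon, ortho to a bromo group, gives no change at the digits printed from compound 1 to compound 3 (within the scatter), so this position does without the methoxy group with no shift beyond the scatter. That reading holds only for the core of compound 1, with its bromo group in place. No measurement given here offers an explanation for this result.

As far as these compounds go, whether an ethoxy group, an amine or a carboxylic acid at this position would move the number stays open. So does whether the same exchange would leave the number unmoved without the bromo group.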